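The source may report more compounds than this note shows. Statements on the series, on what has been measured and on what is new or still open speak of the compounds shown alone.

Working notes on the series, followed along the step from compound 2 to compound 4.

Of the compounds shown here, three have numbers so far. Compound 1, `C[C@H](NC(=O)CN(c1nc(Cl)nc2[nH]cnc12)C1CC1)C(=O)OCc1ccccc1`, gives 64.3% in a functional assay on the whole organism (Tail, strain ICR) with Mus musculus as the target, in the tail flick test, with a stated time of 60 min, at a dose of 25 umol/kg by the oral route; a higher number here means a stronger effect of the compound at the dose given, a lower number a weaker effect. Compound 2, `O=C(CN(c1ncnc2c1ncn2C1CCCCO1)C1CC1)NCC(=O)OCc1ccccc1`, gives 40.4% in this assay. Compound 3, `C[C@@H](O)[C@H](NC(=O)CN(c1nc(Cl)nc2[nH]cnc12)C1CC1)C(=O)O`, gives 30.1% in this assay. Compound 2 thus stands second highest of the three: its nearest neighbour is compound 3, whose number sits lower by a gap beyond the scatter, and the furthest is compound 1, whose number sits higher by a gap beyond the scatter. Compound 1 and compound 2 differ from each other in more than one place, so their gap cannot be assigned to a single change.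

Compound 4, `C[C@H](NC(=O)CN(c1ncnc2c1ncn2C1CCCCO1)C1CC1)C(=O)OCc1ccccc1`, has not been measured in this assay. Against compound 2 the difference is methyl in place of hydrogen on a saturated chain carbon bound to an amide-type nitrogen and a carbonyl carbon. Going by the values given here, no pair of measured compounds differs by exactly this change, so no measured step shows what it does. Compound 1, which carries the same methyl on the same kind of carbon, gives a higher number than compound 2, but its core also differs, which weakens that hint.

The step from compound 2 to compound 4 is expected to be modest and upward, if beyond the scatter at all, as a number 9.6 percentage points higher from compound 2 to compound 4 (within the scatter). Compound 4 is estimated at 50%, within a range from 32% to 68%.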

Compound 4, a percentage reported as activity, at one dose (the size of the read-out at that dose, not a potency): 53%
Compound 4: the middle estimate sits 3 percentage points below what was measured; low and high end bracket the measured number.
By their numbers in this assay, from the lowest: compound 3; then compound 2; then compound 4; then compound 1.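

In this assay, the change of methyl in place of hydrogen on a saturated chain carbon bound to an amide-type nitrogen and a carbonyl carbon now has a reading of its own, with the rest of the structure held constant: a number 12.6 percentage points higher from compound 2 to compound 4 (beyond the scatter). The earlier compounds shown here offered only an indirect hint at this change, since compound 1 carries the same methyl on a different core, whereas this pair isolates the change and shows that this carbon accepts a methyl with a modest gain in the read-out at the dose given. Nothing in the available data bears on why the single added carbon raises the number.

Still open, on these data alone, is whether an ethyl or isopropyl group on this carbon would extend the step or reverse it, and whether the opposite configuration at this carbon would give a similar number. The read-out also reflects one dose and says nothing about potency, and the compounds shown cannot tell whether the same methyl step holds on the core of compound 1.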